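Aryl swap on the carbon double-bonded to nitrogen

The source may report more compounds than this note shows. Statements on the series, on what has been measured and on what is new or still open speak of the compounds shown alone.

Measured compounds in a functional assay on PC-3 cells (Homo sapiens) for inhibition; on this read-out higher numbers stand for weaker inhibition and lower numbers for stronger inhibition:
compound 1 `Cc1c(C(=O)N/N=C\c2cccc(F)c2O)oc2cccc(O)c12` gives 12700 nM;
compound 2 `Cc1ccc(O)c(/C=N\NC(=O)c2oc3cccc(O)c3c2C)c1` gives 7350 nM;
compound 3 `Cc1c(C(=O)N/N=C\c2cc([N+](=O)[O-])ccc2O)oc2cccc(O)c12` gives 17100 nM.

Compound 2 sits at the low end of the three numbers in this assay: the step of a 1.7-fold lower number from compound 1 to compound 2 (0.24 log units; within the scatter) is within the scatter, whereas a 2.3-fold higher number from compound 2 to compound 3 (0.37 log units; beyond the scatter) is modest but beyond it. Compound 4 `Cc1c(C(=O)N/N=C\c2ccc(O)cc2O)oc2cccc(O)c12` is not yet measured. It differs from compound 2 by 2,4-dihydroxyphenyl in place of 2-hydroxy-5-methylphenyl on a carbon with a double bond to nitrogen. Both measured steps alter the same aryl ring, and both partners of compound 2 show higher numbers, one within the scatter. Among the compounds with values here, no measured pair shows a hydroxyl entering, so the direction rests only on that pattern. For compound 4 an expected step of a 1.4-fold higher number from compound 2 to compound 4 (0.13 log units; within the scatter) in this assay seems reasonable. Compound 4 is therefore estimated at 10000 nM, with a range from 4000 nM to 25000 nM.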

Compound 4, half-maximal inhibitory concentration: 14800 nM
The estimate for compound 4 lay 1.5-fold (0.17 log units) below the measured number; measured number inside the range.
By their numbers in this assay, from the lowest: compounds 2, 1, 4 and 3 (each within the scatter of the next, the first and the last beyond it).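

In this assay a second hydroxyl on this aryl ring gives a 2.0-fold higher number from compound 2 to compound 4 (0.30 log units; within the scatter) and a 1.2-fold higher number from compound 1 to compound 4 (0.07 log units; within the scatter) with both steps inside the scatter. Compound 4 therefore does not separate from either partner, and on a carbon with a double bond to nitrogen, 2,4-dihydroxyphenyl reads the same as 2-hydroxy-5-methylphenyl and 3-fluoro-2-hydroxyphenyl. No supporting data bear on the cause of these numbers.

Every aryl group shown carries a hydroxyl, so plain phenyl or a methoxy group in its place remains open. As far as these compounds go, an amine or a carboxylic acid on this ring also remains open.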